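Aryl substituent change on the shared core: cyano to trifluoromethyl

The compounds below may be only part of what the source reports. "The series", "measured", "known", "first", "only" and "open" are said of these compounds alone.

Measured so far:
compound 1 `Cc1ccc(-c2c3c(nn2C(C)C)CCNCC3)cc1` — 4 nM
compound 2 `CC(C)n1nc2c(c1-c1ccc(C#N)cc1)CCNCC2` — 240 nM

Both compounds were run in an ADME assay on membranes from Cortex for displacement of a labelled ligand from Adrenergic receptor alpha-1 (Rattus norvegicus), read by radioligand binding, with a stated time of 60 min; a lower number here means a stronger inhibitor, a higher number a weaker inhibitor. Within the data shown here, compound 2 gives the higher of the two numbers; the only measured step is a 60-fold higher number from compound 1 to compound 2 (1.78 log units; beyond the scatter), and compound 1 stands at the lower end of the pair.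

Compound 3 `CC(C)n1nc2c(c1-c1ccc(C(F)(F)F)cc1)CCNCC2` is not yet measured. Its change from compound 2 is trifluoromethyl in place of cyano on an aromatic carbon. Among the measured compounds shown here, only the step from compound 1 to compound 2 bears on this position on the ring, and that step was large; it shows that the group on this aromatic carbon moves the number well beyond the scatter, but it does not pin down where trifluoromethyl falls relative to cyano or methyl.

For the measured compounds named here, for compound 3 the expected number is 80 nM, with a range of 20 nM to 320 nM; this estimate amounts to a 3.0-fold lower number from compound 2 to compound 3 (0.48 log units; beyond the scatter), a wide range, since no measured step pairs these two groups.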

Compound 3, inhibition constant: 130 nM
Estimate against measurement, compound 3: 1.6-fold (0.21 log units) below, and the stated range covers the measured number.
By their numbers in this assay, from the lowest: compound 1; then compounds 3 and 2 (each within the scatter of the next).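

In this assay, trifluoromethyl in place of cyano on the aromatic carbon para to a large group gives a 1.8-fold lower number from compound 2 to compound 3 (0.27 log units; within the scatter), so these two groups are not separated at this position. Trifluoromethyl in place of methyl gives a 33-fold higher number from compound 1 to compound 3 (1.51 log units; beyond the scatter), so the large gap first seen with cyano recurs with a second group, and among these three compounds methyl alone stands apart, with compound 1 holding the lowest number. No measurement at hand bears on what lies behind this pattern.

Still open, as far as these compounds go, is whether the low number belongs to methyl alone or extends to an ethyl group, a methoxy group or chlorine at this carbon. The shared core with only hydrogen at this position also remains to be placed against these three compounds.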